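The source may report more compounds than this note shows. Statements on the series, on what has been measured and on what is new or still open speak of the compounds shown alone.

Measured in a functional assay on A549 cells (Homo sapiens) for inhibition, read by CCK-8 assay, with a stated time of 72 h, tested at 8 uM; on this read-out lower numbers stand for less inhibition of growth and higher numbers for more inhibition of growth at the one concentration tested:
- compound 1 `Cc1cc(C)cc(SCc2ccc(/C=C/C(=O)Nc3ccccc3N)cc2)c1` gives 47.3%
- compound 2 `Nc1ccccc1NC(=O)/C=C/c1ccc(CSc2ccc(Cl)cc2)cc1` gives 59.6%
- compound 3 `Nc1ccccc1NC(=O)/C=C/c1ccc(CSc2cccc3ccccc23)cc1` gives 71.2%

Compound 3 stands highest of the three, with both gaps beyond the scatter. The change to compound 4 `Nc1ccccc1NC(=O)/C=C/c1ccc(CSCCc2ccccc2)cc1` is phenethyl in place of naphthalen-1-yl on a sulfur. Among the measured compounds shown here, two measured steps bear on it (a number 23.9 percentage points higher from compound 1 to compound 3 (beyond the scatter) and a number 11.6 percentage points higher from compound 2 to compound 3 (beyond the scatter)), both modest rises where naphthalen-1-yl enters at that sulfur. The step of a number 12.3 percentage points higher from compound 1 to compound 2 (beyond the scatter) shows that the two compounds without naphthalen-1-yl also differ from each other by a modest amount. For the measured compounds named here, no measured compound carries phenethyl, and no measured step removes naphthalen-1-yl in favour of it, so the transfer is loose and the range is kept wide. A modest fall is expected in this assay with an estimated a number 16.2 percentage points lower from compound 3 to compound 4 (beyond the scatter) as its size. Compound 4 is estimated at 55% with an expected range from 40% to 70% on this read-out.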

Compound 4, percent growth inhibition at one concentration: 50.3%
Estimate against measurement, compound 4: 4.7 percentage points above, within the range that was stated.
By their numbers in this assay, from the lowest: compounds 1, 4 and 2 (each within the scatter of the next, the first and the last beyond it); then compound 3.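

In this assay, phenethyl, with one six-membered aromatic ring in place of the two of naphthalen-1-yl, does not hold the level of the naphthalen-1-yl compound: a number 20.9 percentage points lower from compound 3 to compound 4 (beyond the scatter). Set against the two other one-ring groups on this sulfur, phenethyl shows a number 9.3 percentage points lower from compound 2 to compound 4 (within the scatter) and a number 3 percentage points higher from compound 1 to compound 4 (within the scatter), so among the four compounds only naphthalen-1-yl stands clear of all the others, while a saturated chain carbon in the group on the sulfur does not separate compound 4 from compound 1 or compound 2. No supporting data bear on why this position responds in this way.

Still open, on these data alone, is whether the high number follows the second aromatic ring itself or its particular attachment, which naphthalen-2-yl or 2-(naphthalen-1-yl)ethyl on the sulfur would test. As far as these compounds go, how a group carrying an amine or a carboxylic acid would read at this position also remains open.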